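Swapping a Dichlorobenzyl Sulfone for a Methylbenzyl Sulfone

The compounds below may be only part of what the source reports. "The series", "measured", "known", "first", "only" and "open" are said of these compounds alone.

Compound 1 `Cc1ccc(/C=C(\C(=O)c2ccc(Cl)cc2)S(=O)(=O)Cc2ccc(Cl)cc2Cl)s1` was tested in a functional assay on DU-145 cells (Homo sapiens) for inhibition, read by trypan blue exclusion, with a stated time of 96 h (on this read-out lower numbers stand for stronger inhibition of growth and higher numbers for weaker inhibition of growth), where compound 1 gives 10000 nM. Two related compounds were measured in the same way: compound 2 `Cc1ccc(C)c(/C=C(/Sc2ccc(Br)cc2)C(=O)c2ccc(Cl)cc2)c1` gives 10000 nM, and compound 3 `CCOc1ccc(/C=C(\C(=O)c2ccc(Br)cc2)S(=O)(=O)c2ccc(Br)cc2)c(OCC)c1` gives 10000 nM. Compound 1 therefore stands level with both of them; all three readings lie within the usual scatter of one another, so none of the three can be called weaker or stronger.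

Compound 4 `Cc1ccc(CS(=O)(=O)/C(=C/c2ccc(C)s2)C(=O)c2ccc(Cl)cc2)cc1` has not yet been measured. It differs from compound 1 in one place: 4-methylphenyl in place of 2,4-dichlorophenyl on a saturated chain carbon bound to a sulfonyl sulfur. Among the measured compounds shown here, no pair of measured compounds differing in a single place is available to calibrate this change, and every measured compound sits at the same reading, so the step is expected to be no change at the digits printed from compound 1 to compound 4 (within the scatter), nothing beyond the scatter. Compound 4 is accordingly estimated at 10000 nM, with an expected range from 5000 nM to 20000 nM.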

Compound 4, concentration for 50% growth inhibition: 25000 nM
The estimate for compound 4 lay 2.5-fold (0.40 log units) below the measured number; the measured number lies above the stated range.
By their numbers in this assay, from the lowest: compounds 1, 2 and 3 (each within the scatter of the next); then compound 4.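

In this assay, 4-methylphenyl in place of 2,4-dichlorophenyl on a saturated chain carbon bound to a sulfonyl sulfur gives a 2.5-fold higher number from compound 1 to compound 4 (0.40 log units; beyond the scatter), a modest weakening of growth inhibition. This first single-place comparison shows that the group held here can shift the reading beyond the scatter. No available data explain the shift.

The swap removes both chlorines and adds a methyl, so the contribution of each remains unresolved. Also open, from the compounds shown here alone, is how an amine or a carboxylic acid on this phenyl ring would read.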